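Fluorophenyl Swap Beneath a Cytotoxicity Limit

A few compounds are considered here, and "the series" means these few. Any claim that something is new, unique, unknown or untested is made for them only; others in the source may bear on it.

In an ADME assay on HEK293 cells (Homo sapiens) for cytotoxicity, read by CellTiter-Glo and resazurin assay, with a stated time of 72 h (a higher number here means that more compound is needed for the effect, a lower number that less compound is needed), compound 1 `CC(C)N(Cc1cccc(OCCCCCC(=O)O)c1)C(=O)c1ccc(-c2cccc(OC(F)(F)F)c2)cc1` gives > 26000 nM, a limit rather than a number. Compound 2 `CCOC(=O)CCCCCOc1cccc(CN(C(=O)c2ccc(-c3cnc(OC)nc3OC)cc2)C(C)C)c1` likewise returns only the limit > 26000 nM in this assay. Going by the values given here, because of the limit of > 26000 nM in this assay, at which 2 of the 2 values shown sit, compound 2 stands exactly where every value so far rests, with no measured number anywhere to set a scale. Compound 3 `CCOC(=O)CCCCCOc1cccc(CN(C(=O)c2ccc(-c3cccc(F)c3)cc2)C(C)C)c1` differs from compound 2 by 3-fluorophenyl in place of 2,4-dimethoxypyrimidin-5-yl on an aromatic carbon. Among the compounds with values here, no step between measured compounds exists here. The step that the limit leaves unreadable from compound 2 to compound 3 is expected to stay within the scatter, so no real movement is anticipated. Compound 3 is therefore estimated at 30000 nM, within 15000 nM to 80000 nM.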

Compound 3, half-maximal effective concentration: > 26000 nM
Compound 3: only a limit was reported; the forecaster's own chance of this, stated with the estimate: 80%; the middle value is on the limit's open side.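

Compound 2 and compound 3 both rest on a limit, so no step can be read between them: the limit of > 26000 nM in this assay, at which 3 of the 3 values shown sit.

Whether 3-fluorophenyl and 2,4-dimethoxypyrimidin-5-yl differ at all in this assay stays open, as does the concentration giving a half-maximal effect for any compound shown.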